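Lengthening the Ester Chain of Compound 2

This account rests on a few compounds, and the source may have more. Where it says the series, first, only, none or still open, it means among the compounds named here.

Compound 1 `CC(C)c1cccc(C(C)C)c1OC(=O)CC(=O)Nc1ccccc1`: in an assay on microsomes from intestine for inhibition of acyl-CoA:cholesterol acyltransferase (Oryctolagus cuniculus) (a lower number here means a stronger inhibitor, a higher number a weaker inhibitor), compound 1 gives > 5000 nM, which is a limit of the assay, not a number (the limit of > 5000 nM in this assay, at which 1 of the 3 values shown sits).
Compound 2 `CCOC(=O)CC(=O)Nc1c(C(C)C)cccc1C(C)C`: in this assay compound 2 gives 1800 nM.
Compound 3 `CCCCCCCCCCCC[C@H](C)OC(=O)CC(=O)Nc1c(C(C)C)cccc1C(C)C`: in this assay compound 3 gives 4 nM.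

Among the two numbers, compound 2 stands highest; the nearest is compound 3, whose number lies far lower, well beyond the scatter. Compound 4 `CCCCCCOC(=O)CC(=O)Nc1c(C(C)C)cccc1C(C)C` differs from compound 2 by butyl in place of hydrogen on a saturated chain carbon, two bonds along the chain from an oxygen next to a carbonyl group. Compound 3, which also carries a long chain in place of the ethyl, gives 4 nM, so a large step down is expected from compound 2 to compound 4, though the hexyl chain is shorter than that of compound 3. Compound 4 is expected to give about 150 nM, between 30 nM and 800 nM, an expected step of a 12-fold lower number from compound 2 to compound 4 (1.08 log units; beyond the scatter).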

Compound 4, half-maximal inhibitory concentration: 810 nM
Beside the measured number, compound 4's estimate is 5.4-fold (0.73 log units) below it; measured number above the stated range.
By their numbers in this assay, from the lowest: compound 3; then compound 4; then compound 2. At a limit, above all of these: compound 1.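

Going from ethyl to hexyl on the ester gives a 2.2-fold lower number from compound 2 to compound 4 (0.35 log units; beyond the scatter) in this assay. This shows that the chain at this position can grow by a butyl group with the number still falling, though only modestly. Nothing measured here accounts for the size of this step.

Still open, on these data alone, is how a longer chain alone would behave, since compound 3, with its much longer chain and a methyl branch, gives 4 nM and differs from compound 4 in more than length. Also open, as far as these compounds go, is what an amine or a carboxylic acid at the end of the chain would do.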